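Acetyl on the aromatic ring of two related phenols

A few compounds are considered here, and "the series" means these few. Any claim that something is new, unique, unknown or untested is made for them only; others in the source may bear on it.

Compound 1 `Oc1cc2c(cc1CNc1ccccc1)OCCC2` and compound 2 `CC(=O)c1ccc(NCc2cc3c(cc2O)CCCO3)cc1` share one core and differ in a single group. In a physicochemical assay for lipophilicity (a lower number here means a more polar compound, a higher number a more lipophilic compound), compound 1 gives 3.5, and compound 2 gives 3.5. The change between them is acetyl in place of hydrogen on an aromatic carbon, and the step it made is no change at the digits printed from compound 1 to compound 2 (within the scatter). Compound 3 `Oc1cc2c(cc1CNc1ccccc1)OCC2` has a different core; how the two cores differ is not broken down here. In this assay compound 3 gives 2.9, lower than both of the others. Compound 4 `CC(=O)c1ccc(NCc2cc3c(cc2O)CCO3)cc1` has not yet been measured; it arises from compound 3 by acetyl in place of hydrogen on an aromatic carbon, the same change as from compound 1 to compound 2 at the same place. For compound 4 the step is expected to be no change at the digits printed from compound 3 to compound 4 (within the scatter), because no change at the digits printed from compound 1 to compound 2 (within the scatter). Compound 4 is therefore estimated at 2.9, between 2.6 and 3.2.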

Compound 4, partition coefficient: 2.9
For compound 4 middle estimate and measured number coincide at the digits printed; the measured number falls inside the stated range.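

In this assay acetyl in place of hydrogen on an aromatic carbon gives no change at the digits printed from compound 3 to compound 4 (within the scatter) and so matches the earlier no change at the digits printed from compound 1 to compound 2 (within the scatter) on the other core, which means that in these two pairs the change carries across from one core to the other. Two pairs on two cores show only that much and do not establish a rule for further cores in this series. Nothing shown here explains why the two steps agree.

The compounds shown vary this place only between hydrogen and acetyl. Going by these compounds, whether this assay would respond in the same way on both cores to an amine, a carboxylic acid or a longer chain at this place remains open.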